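Compound 4: benzyloxy in place of 5-hydroxypentyl

This account rests on a few compounds, and the source may have more. Where it says the series, first, only, none or still open, it means among the compounds named here.

Measured in a functional assay on NCI-H460 cells (Homo sapiens); a higher number here means a weaker inhibitor, a lower number a stronger inhibitor:
- compound 1 `COc1cc(NC(C)CCCNC(=O)NCCO)c2ncccc2c1`: > 100000 nM (a limit)
- compound 2 `COc1cc(NC(C)CCCNC(=O)NCCCO)c2ncccc2c1`: > 100000 nM (a limit)
- compound 3 `COc1cc(NC(C)CCCNC(=O)NCCCCCO)c2ncccc2c1`: 2000 nM

Among the compounds with values here, compound 3 gives the only actual number in this assay. The rest of the set sits at the limit of > 100000 nM in this assay, at which 2 of the 3 values shown sit.

Next is compound 4 `COc1cc(NC(C)CCCNC(=O)NOCc2ccccc2)c2ncccc2c1`, which differs from compound 3 as follows: benzyloxy in place of 5-hydroxypentyl on an amide-type nitrogen. The terminal hydroxy group of the chain is therefore lost, and the shared core stays unchanged.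

Within the data shown here, three measured steps bear on this change, all on the same amide-type nitrogen. Two are large: an at least 50-fold lower number from compound 1 to compound 3 (1.69 log units; beyond the scatter) and an at least 50-fold lower number from compound 2 to compound 3 (1.69 log units; beyond the scatter). The third, a step that the two limits leave unreadable from compound 1 to compound 2, has no readable size. None of them introduces benzyloxy, so they show that this substituent can matter greatly but give no direct size for the new step. A moderate loss is expected, with a real chance that compound 4 reaches the limit of the assay.

The estimated step is a 3.5-fold higher number from compound 3 to compound 4 (0.54 log units; beyond the scatter). For compound 4 the expected value is 7000 nM, with an estimated range from 1200 nM to 50000 nM.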

Compound 4, half-maximal inhibitory concentration: 21000 nM
For compound 4 the middle estimate is 3.0-fold (0.48 log units) below the measured one; the measured number falls inside the stated range.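

In this assay, compound 4 shows that a readable number on this amide-type nitrogen does not depend on a chain ending in hydroxy, since benzyloxy carries no such group. The change still costs strength, with an 11-fold higher number from compound 3 to compound 4 (1.02 log units; beyond the scatter), while the shorter hydroxy chains fall behind benzyloxy, with an at least 4.7-fold lower number from compound 2 to compound 4 (0.67 log units; beyond the scatter) and an at least 4.7-fold lower number from compound 1 to compound 4 (0.67 log units; beyond the scatter). Both of these last steps are lower bounds, as compounds 1 and 2 are limits and not numbers: the limit of > 100000 nM in this assay, at which 2 of the 4 values shown sit.

What remains open is which part of benzyloxy accounts for its standing, the ring or the oxygen on the nitrogen, which a plain benzyl group would separate. Also open, as far as these compounds go, is whether chain length or the terminal hydroxy drives compound 3, which an unsubstituted pentyl chain, a pentyl chain ending in an amine or a longer hydroxy chain would test.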